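Inverting One Stereocentre on the Acetylpiperidine Ether

The source may hold more compounds than are shown below. What is called first, only, known or untested is meant among the compounds shown, and "the series" means these compounds.

In an ADME assay on a cell-free system (plasma, Rattus norvegicus, strain Sprague-Dawley) for protein binding, compound 1 `O=C(Nc1cc(F)cc(Oc2cccnc2)c1)c1ccc(F)cc1` gives 92.1% and compound 2 `O=C(Nc1cccnc1)Nc1cc(F)cc(Oc2cccnc2)c1` gives 92.9%, a pair separated by a 1.1-fold lower unbound fraction from compound 1 to compound 2 (0.05 log units; within the scatter). Compound 3 `CC(=O)N1CCC[C@@H](Oc2cc(F)cc(NC(=O)Nc3cccnc3)c2)C1`, at 82.5%, has the highest unbound fraction of the three, and replacing pyridin-3-yl with 1-acetylpiperidin-3-yl on the oxygen gave a 2.5-fold higher unbound fraction from compound 2 to compound 3 (0.39 log units; beyond the scatter). Compound 4 `CC(=O)N1CCC[C@H](Oc2cc(F)cc(NC(=O)Nc3cccnc3)c2)C1` changes only the drawn configuration: the two compounds have the same atoms and bonds and differ only in configuration as drawn: 1 of 1 stereo elements differ; a stereocentre at a saturated ring carbon is drawn R in compound 3 and S in compound 4. Neither measured step tests a change of configuration, since each replaces a group. Their sizes therefore offer no direct guide, and no shift beyond the scatter is expected in this assay. The estimated change is a 1.0-fold lower unbound fraction from compound 3 to compound 4 (0.01 log units; within the scatter). Compound 4 is expected at 83%, with an estimated range of 73% to 90%.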

Compound 4, plasma protein binding: 82.5%
Compound 4: the middle estimate sits 1.0-fold (0.01 log units) (unbound fraction) below what was measured, within the range that was stated.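

In this assay, the configuration at this saturated ring carbon has no detectable effect: no change at the digits printed from compound 3 to compound 4 (within the scatter). The comparison isolates this one stereocentre, as no other structural feature varies: the fact that compounds 3 and 4 differ only in the configuration as drawn. The shift seen on placing 1-acetylpiperidin-3-yl on the oxygen in place of pyridin-3-yl is therefore not confined to the R form, with the S form giving a 2.5-fold higher unbound fraction from compound 2 to compound 4 (0.39 log units; beyond the scatter). On these data alone, it remains open how the unbound fraction would respond if a free amine or a methanesulfonyl group replaced the acetyl on the piperidine. Whether the R and S forms would still match with such a group is also unresolved.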